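Branching the butoxy chain: compound 2 to compound 3

The source may report more compounds than this note shows. Statements on the series, on what has been measured and on what is new or still open speak of the compounds shown alone.

Measured so far:
- compound 1 `CC(C)=CCOc1cccc(O)c1C(=O)/C=C/c1ccc(O)cc1`: > 30000 nM
- compound 2 `CCCCOc1cccc(O)c1C(=O)/C=C/c1ccc(O)cc1`: > 30000 nM

In a functional assay on HCT-15 cells (Homo sapiens) for antiproliferative activity, read by sulforhodamine B assay (on this read-out lower numbers stand for stronger inhibition of growth and higher numbers for weaker inhibition of growth), compound 2 gives > 30000 nM, which is a limit and not a number. Compound 1 gives > 30000 nM, also a limit. Going by the values given here, the series so far therefore stands at one point: the limit of > 30000 nM in this assay, at which 2 of the 2 values shown sit.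

Compound 3 `CC(C)COc1cccc(O)c1C(=O)/C=C/c1ccc(O)cc1` keeps the shared core and changes only the chain: isopropyl in place of propyl on a saturated chain carbon bound to an oxygen on an aromatic ring. In words, isopropyl takes the place of propyl on a saturated chain carbon bound to an oxygen on an aromatic ring, turning butoxy to isobutoxy.

Among the compounds with values here, the only measured step is a step that the two limits leave unreadable from compound 1 to compound 2, so it offers no size to carry over. No step beyond the scatter is therefore expected in this assay, in either direction. The estimated step is a number no higher from compound 2 to compound 3 (the limit leaves the size open). For compound 3 the expected value is 30000 nM, with an estimated range of 12000 nM to 60000 nM.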

Compound 3, concentration for 50% growth inhibition: 2600 nM
Compound 3: the middle estimate sits 12-fold (1.06 log units) above what was measured, outside the stated range (below it).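

In this assay, the position on the saturated chain carbon bound to an oxygen on an aromatic ring now gives a readable response, with butoxy to isobutoxy producing an at least 11-fold lower number from compound 2 to compound 3 (1.06 log units; beyond the scatter). The same atoms, joined differently, therefore separate a limit from a measured number, a distinction the earlier compounds could not show: the limit of > 30000 nM in this assay, at which 2 of the 3 values shown sit.
Isopropyl in place of 2-methylprop-1-en-1-yl gives an at least 11-fold lower number from compound 1 to compound 3 (1.06 log units; beyond the scatter), so a branched chain end alone does not account for the gain, since compound 1 also carries one.

As far as these compounds go, the true size of both steps remains open, as each starts from a limit and not a number. Going by these compounds alone, with compound 3 as the only measured number, it is also open whether a longer branched chain or a chain ending in an amine would keep this activity.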